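From methylsulfanyl to trifluoromethyl on a shared core

This account rests on a few compounds, and the source may have more. Where it says the series, first, only, none or still open, it means among the compounds named here.

Measured in an ADME assay on WI-38 cells (Homo sapiens) for cytotoxicity, read by MTT assay, with a stated time of 72 h; a higher number here means a weaker inhibitor, a lower number a stronger inhibitor:
- Compound 1 `O=C(CCc1cccc2c1B(O)OC2)Nc1cccc(-c2ccc(Cl)cc2)c1` gives 9800 nM
- Compound 2 `O=C(CCc1cccc2c1B(O)OC2)Nc1cccc(-c2ccc(OC(F)(F)F)cc2)c1` gives 25000 nM
- Compound 3 `CSc1ccc(-c2cccc(NC(=O)CCc3cccc4c3B(O)OC4)c2)cc1` gives 3800 nM

In this assay compound 3 has the lowest number of the three, at 3800 nM. The next step leads to compound 4 `O=C(CCc1cccc2c1B(O)OC2)Nc1cccc(-c2ccc(C(F)(F)F)cc2)c1`, which carries trifluoromethyl in place of methylsulfanyl on an aromatic carbon, para to a large group: trifluoromethyl in place of methylsulfanyl on an aromatic carbon. For the measured compounds named here, no measured step has trifluoromethyl on either side, so the expectation is indirect. Two measured steps bring in methylsulfanyl, and both lower the number: a 2.6-fold lower number from compound 1 to compound 3 (0.41 log units; beyond the scatter) and a 6.6-fold lower number from compound 2 to compound 3 (0.82 log units; beyond the scatter). Removing methylsulfanyl is therefore expected to raise the number, by a modest amount within the span of those two steps. The expected step is a 3.9-fold higher number from compound 3 to compound 4 (0.60 log units; beyond the scatter). The estimated value for compound 4 is 15000 nM, with an expected range from 6000 nM to 35000 nM.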

Compound 4, half-maximal inhibitory concentration: 26000 nM
The estimate for compound 4 lay 1.7-fold (0.24 log units) below the measured number; the range from low to high includes it.
By their numbers in this assay, from the lowest: compound 3; then compound 1; then compounds 2 and 4 (each within the scatter of the next).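

Trifluoromethyl on this aromatic carbon, para to a large group, now reads directly against methylsulfanyl (a 6.8-fold higher number from compound 3 to compound 4 (0.84 log units; beyond the scatter)) and against chloro (a 2.7-fold higher number from compound 1 to compound 4 (0.42 log units; beyond the scatter)), so in this assay both of those groups give lower numbers than trifluoromethyl does. Trifluoromethyl and trifluoromethoxy cannot be told apart here (a 1.0-fold higher number from compound 2 to compound 4 (0.02 log units; within the scatter)), which means that the two fluorine-bearing groups together stand above chloro, and chloro above methylsulfanyl, across all four compounds. Nothing available explains these differences.

From the compounds shown here alone, whether an amine, a carboxylic acid or a longer chain on this carbon would fall within the same span remains open. Going by these compounds, it is also open whether this ordering of the four groups would hold with any other change to the shared core.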